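Notes on the step from compound 3 to compound 4

The source may report more compounds than this note shows. Statements on the series, on what has been measured and on what is new or still open speak of the compounds shown alone.

Measured so far in a functional assay on DU-145 cells (Homo sapiens) for inhibition, read by trypan blue exclusion, with a stated time of 96 h (a lower number here means a stronger inhibitor of growth, a higher number a weaker inhibitor of growth), for three compounds
Compound 1 `Cc1ccc(/C=C(\C(=O)c2ccc([N+](=O)[O-])cc2)S(=O)(=O)Cc2ccc(Cl)cc2)s1` gives 25000 nM
Compound 2 `COc1ccccc1/C=C(\C(=O)c1ccc([N+](=O)[O-])cc1)S(=O)(=O)Cc1ccc(Cl)cc1` gives 10000 nM
Compound 3 `COc1cc(OC)c(/C=C(\C(=O)c2ccc([N+](=O)[O-])cc2)S(=O)(=O)Cc2ccc(Cl)cc2)c(OC)c1` gives 10000 nM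

Compound 3 shares the lowest number of the three, as no change at the digits printed from compound 2 to compound 3 (within the scatter) shows, and a 2.5-fold lower number from compound 1 to compound 3 (0.40 log units; beyond the scatter) sets it apart from the third member. The next structure is compound 4 `Cc1ccsc1/C=C(\C(=O)c1ccc([N+](=O)[O-])cc1)S(=O)(=O)Cc1ccc(Cl)cc1` and the change is 3-methylthiophen-2-yl in place of 2,4,6-trimethoxyphenyl on a double-bonded chain carbon bound to a double-bonded chain carbon with 3-methylthiophen-2-yl in place of 2,4,6-trimethoxyphenyl. Among the measured compounds shown here, two measured steps bear on this change. Leaving 5-methylthiophen-2-yl gave a 2.5-fold lower number from compound 1 to compound 2 (0.40 log units; beyond the scatter) and a 2.5-fold lower number from compound 1 to compound 3 (0.40 log units; beyond the scatter) and both are modest. For the measured compounds named here, no measured compound carries 3-methylthiophen-2-yl, so the closest guide is a differently methylated thiophene. Compound 4 is therefore expected to sit near compound 1, which gives 25000 nM in this assay at the high end of the set. A modest rise is expected, estimated as a 2.2-fold higher number from compound 3 to compound 4 (0.34 log units; beyond the scatter) in this assay on this reading. Compound 4 is expected at 22000 nM within an estimated range from 9000 nM to 50000 nM overall.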

Compound 4, concentration for 50% growth inhibition: 1000 nM
For compound 4 the middle estimate is 22-fold (1.34 log units) above the measured one, and the stated range ends above it.
By their numbers in this assay, from the lowest: compound 4; then compounds 2 and 3 (each within the scatter of the next); then compound 1.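

At this place, on a double-bonded chain carbon bound to a double-bonded chain carbon, a methylthiophene does not fix the level in this assay: 3-methylthiophen-2-yl in place of 5-methylthiophen-2-yl gives a 25-fold lower number from compound 1 to compound 4 (1.40 log units; beyond the scatter) and so separates two groups of the same atom count by the largest step in the set. The methoxyphenyl compounds also no longer mark the low end, with a 10-fold lower number from compound 2 to compound 4 (1.00 log units; beyond the scatter) and a 10-fold lower number from compound 3 to compound 4 (1.00 log units; beyond the scatter) leaving compound 4 alone at the bottom of the set. Nothing available here accounts for the gap between the two methylthiophenes.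

Whether the methyl group itself matters stays open, since an unsubstituted thiophen-2-yl does not appear among these compounds. Also open, from the compounds shown here alone, is whether an ethyl group or a chlorine atom could replace that methyl without losing the low number of compound 4.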